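This account rests on a few compounds, and the source may have more. Where it says the series, first, only, none or still open, it means among the compounds named here.

Measured so far in a functional assay on SH-SY5Y cells (Homo sapiens) for cytotoxicity, read by MTT assay, with a stated time of 72 h (on this read-out lower numbers stand for stronger inhibition and higher numbers for weaker inhibition), and still open:
compound 1 `CN(C)CCCCCn1c2c(c3ccccc31)C(=O)c1c[n+]([O-])c3ccccc3c1C2=O` gives 370 nM
compound 2 `O=C1c2c[n+]([O-])c3ccccc3c2C(=O)c2c1c1ccccc1n2CCCCN1CCNCC1` gives 1240 nM
compound 3 `O=C1c2c[n+]([O-])c3ccccc3c2C(=O)c2c1c1ccccc1n2CCN1CCCCC1` has no value yet

Of the two numbers, compound 2 at 1240 nM is the higher. The move to compound 3 is piperidin-1-yl in place of 2-(piperazin-1-yl)ethyl on a saturated chain carbon, two bonds along the chain from an aromatic nitrogen and reads as piperidin-1-yl in place of 2-(piperazin-1-yl)ethyl on a saturated chain carbon, two bonds along the chain from an aromatic nitrogen. Among the measured compounds shown here, only one measured step bears on this, and it is modest: a 3.4-fold higher number from compound 1 to compound 2 (0.53 log units; beyond the scatter) with piperazin-1-yl entering. Since that group leaves again in compound 3, a modest move toward a lower number is expected in this assay on this single step. The expected change is a 1.8-fold lower number from compound 2 to compound 3 (0.25 log units; within the scatter) and it may fall within the scatter. Compound 3 is estimated at 700 nM with an expected range of 250 nM to 2000 nM overall.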

Compound 3, half-maximal inhibitory concentration: 1860 nM
Beside the measured number, compound 3's estimate is 2.7-fold (0.42 log units) below it, within the range that was stated.
By their numbers in this assay, from the lowest: compound 1; then compounds 2 and 3 (each within the scatter of the next).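

In this assay, going from 4-(piperazin-1-yl)butyl to 2-(piperidin-1-yl)ethyl gives a 1.5-fold higher number from compound 2 to compound 3 (0.18 log units; within the scatter), so the loss of piperazin-1-yl does not bring the number back toward that of compound 1 at this position. Against the dimethylamino chain, the same end group and chain give a 5.0-fold higher number from compound 1 to compound 3 (0.70 log units; beyond the scatter), which leaves compound 1 with the lowest number of the three, its steps to both others being beyond the scatter. No measurement on hand accounts for either step.

Compound 3 differs from compound 2 in both ring and chain, so the share of each stays unresolved. A 4-(piperidin-1-yl)butyl or a 2-(dimethylamino)ethyl group at this position would separate the end group from the chain, and a morpholin-4-yl end group would extend the comparison of rings.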